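The compounds below may be only part of what the source reports. "The series", "measured", "known", "first", "only" and "open" are said of these compounds alone.

Measured so far:
compound 1 `COc1cc2c(cc1O)CCC(C)(CC(=O)N[C@@H](C)C(=O)O)O2` — 94.6%
compound 2 `COc1cc2c(cc1O)CCC(C)(CC(N)=O)O2` — 100%

Both numbers come from an ADME assay on SH-SY5Y cells (Homo sapiens) for cytotoxicity, read by MTT assay, with a stated time of 24 h, tested at 6.3 uM; a higher number here means a weaker effect of the compound at the concentration tested, a lower number a stronger effect. Compound 2 stands with compound 1 inside a single band of scatter: a number 5.4 percentage points higher from compound 1 to compound 2 (within the scatter). Compound 3 `COc1cc2c(cc1O)CCC(C)(CC(=O)N[C@@H](CCC(N)=O)C(=O)O)O2` is not yet measured in this assay and differs from compound 2 by 3-carbamoyl-1-carboxypropyl in place of hydrogen on an amide-type nitrogen. For the measured compounds named here, the only measured step that bears on this change is the one at the same nitrogen, a number 5.4 percentage points higher from compound 1 to compound 2 (within the scatter), which stayed within the scatter. No step beyond the scatter is therefore expected, and the step in this assay is estimated as a number 4 percentage points lower from compound 2 to compound 3 (within the scatter). For compound 3 a value of 96% is expected, in a range from 85% to 104%.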

Compound 3, a percentage reported as activity, at one concentration (the size of the read-out at that concentration, not a potency): 84%
Estimate against measurement, compound 3: 12 percentage points above; the measured number lies below the stated range.
By their numbers in this assay, from the lowest: compound 3; then compounds 1 and 2 (each within the scatter of the next).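

In this assay the amide-type nitrogen is not indifferent to its substituent: 3-carbamoyl-1-carboxypropyl there gives a number 16 percentage points lower from compound 2 to compound 3 (beyond the scatter) while the smaller 1-carboxyethyl group stayed within the scatter. Carbamoylmethyl in place of hydrogen on the saturated chain carbon gives a number 10.6 percentage points lower from compound 1 to compound 3 (beyond the scatter) and so marks the added side chain as the part that separates these substituents in this series. Nothing available explains this step.

Open, from the compounds shown here alone, is whether the terminal carbamoyl matters as such: a carboxylic acid or an amine at that chain end, or a longer chain, could separate it from chain length alone.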